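Urea Side Chain Swap Beside the Assay Ceiling

The source may hold more compounds than are shown below. What is called first, only, known or untested is meant among the compounds shown, and "the series" means these compounds.

Going by the values given here, compound 2 `Cc1cccc(NC(=O)Nc2ccc(Oc3ncnc4[nH]ncc34)cc2)c1C` is the only member of this set with a numbered result: in an assay on isolated protein for inhibition of vascular endothelial growth factor receptor 2 (Danio rerio), read by fluorescence and microscopy, with a stated time of 33 h (a lower number here means a stronger inhibitor, a higher number a weaker inhibitor), compound 2 gives 98800 nM. Compound 1 `Cc1cccc(NC(=O)Nc2ccc(Nc3ncnc4[nH]ncc34)cc2)c1C` reaches only a limit of the assay, and in this assay compound 1 gives > 100000 nM. Compound 3 `O=C(Nc1cccc(Oc2ncnc3[nH]ncc23)c1)c1ccc(C(F)(F)F)cc1` likewise sits at a limit, and in this assay compound 3 gives > 100000 nM. Two of the three values therefore rest at the limit of > 100000 nM in this assay, at which 2 of the 3 values shown sit, and the number for compound 2 stands close beside it. Compound 4 `O=C(NCC1CCCCC1)Nc1ccc(Oc2ncnc3[nH]ncc23)cc1` has not yet been measured. It differs from compound 2 in one place: cyclohexylmethyl in place of 2,3-dimethylphenyl on an amide-type nitrogen. Among the compounds with values here, no pair of measured compounds differing in a single place exists here, so no measured step guides the size of this change. Because compound 2 stands near the limit of > 100000 nM in this assay, at which 2 of the 3 values shown sit, and the other two compounds sit at it, the author expects no step beyond the scatter in this assay, with a fair chance that compound 4 again returns only a limit. Compound 4 is expected to give 100000 nM, within a range from 30000 nM to 300000 nM. The step from compound 2 to compound 4 is accordingly estimated at a 1.0-fold higher number from compound 2 to compound 4 (0.01 log units; within the scatter).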

Compound 4, half-maximal inhibitory concentration: > 100000 nM
Compound 4 gave a limit, no number; the forecaster's own chance of this, stated with the estimate: 60%; the middle value sits exactly at the limit.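

In this assay compound 4 gives > 100000 nM, which is a limit of the assay and not a number. Going by these compounds alone, this supplies the first step in the set between two compounds that differ in one place: cyclohexylmethyl in place of 2,3-dimethylphenyl on an amide-type nitrogen gives an at least 1.0-fold higher number from compound 2 to compound 4 (0.00 log units; that floor lies within the scatter), a floor with no upper end. Exchanging the aromatic ring for a non-aromatic ring of carbon only therefore returned no number clear of the limit at this position, and most of the set now rests there: the limit of > 100000 nM in this assay, at which 3 of the 4 values shown sit.

On these data alone, the true size of this step stays open. As far as these compounds go, whether a longer chain on that nitrogen, or a cyclohexylmethyl carrying an amine or a carboxylic acid, would return a number clear of the limit also stays open.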